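This account rests on a few compounds, and the source may have more. Where it says the series, first, only, none or still open, it means among the compounds named here.

Measured compounds in a functional assay on Huh-7 cells (Homo sapiens) for antiproliferative activity, read by CCK-8 assay, with a stated time of 72 h; on this read-out higher numbers stand for weaker inhibition of growth and lower numbers for stronger inhibition of growth:
compound 1, `CC[C@@H]1C(=O)N(C)c2cnc(-n3ccc4cc(C(=O)NC(C)C)ccc43)nc2N1C1CCCC1`, gives 1660 nM
compound 2, `CC[C@@H]1C(=O)N(C)c2cnc(-n3ccc4cc(C(=O)NCC(C)C)ccc43)nc2N1C1CCCC1`, gives "not active" (no number reported), reported without a number
compound 3, `CC[C@@H]1C(=O)N(C)c2cnc(-n3ccc4cc(C(=O)NC)ccc43)nc2N1C1CCCC1`, gives 842 nM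

In this assay compound 3 gives 842 nM, the lowest of the two numbers reported. Its nearest neighbour is compound 1 with 1660 nM; the step of a 2.0-fold lower number from compound 1 to compound 3 (0.29 log units; within the scatter) lies within the scatter, so no order between compound 1 and compound 3 can be read from these two figures. Compound 2, the isobutyl amide, was reported as not active in this assay and has no number.

Compound 4, `CCCNC(=O)c1ccc2c(ccn2-c2ncc3c(n2)N(C2CCCC2)[C@H](CC)C(=O)N3C)c1`, differs from compound 3 by ethyl in place of hydrogen on a saturated chain carbon bound to an amide-type nitrogen. Among the compounds with values here, the only measured step that bears on this is a 2.0-fold lower number from compound 1 to compound 3 (0.29 log units; within the scatter), which was within the scatter. Compound 2, with its isobutylcarbamoyl, gave no activity, which leaves open that the propylcarbamoyl of compound 4 may give a somewhat higher number than compound 3. A modest rise of about a 1.8-fold higher number from compound 3 to compound 4 (0.25 log units; within the scatter) is therefore expected for compound 4, with a step within the scatter also plausible. For compound 4 a value of 1500 nM is estimated, with a range from 600 nM to 4000 nM in this assay.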

Compound 4, concentration for 50% growth inhibition: 689 nM
The estimate for compound 4 lay 2.2-fold (0.34 log units) above the measured number; the range from low to high includes it.
By their numbers in this assay, from the lowest: compounds 4, 3 and 1 (each within the scatter of the next, the first and the last beyond it).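

In this assay the amide nitrogen accepts propyl as readily as methyl: ethyl in place of hydrogen on the saturated chain carbon bound to the amide-type nitrogen gives a 1.2-fold lower number from compound 3 to compound 4 (0.09 log units; within the scatter), with no readable change. Propyl in place of isopropyl gives a 2.4-fold lower number from compound 1 to compound 4 (0.38 log units; beyond the scatter), a modest step and the first in this set beyond the scatter, so these two chains can be told apart at this position, while compound 2 with isobutylcarbamoyl stays without a number. No measurement at hand accounts for these differences between chains on the amide nitrogen.

From the compounds shown here alone, whether a straight butyl or longer chain keeps the activity seen with propylcarbamoyl remains open. So does the effect of a chain ending in an amine or a carboxylic acid, and of the unsubstituted carboxamide.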